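The source may report more compounds than this note shows. Statements on the series, on what has been measured and on what is new or still open speak of the compounds shown alone.

Of the compounds shown here, three sharing a core have been measured in a functional assay on MV4-11 cells (Homo sapiens) for antiproliferative activity, read by CCK-8 assay, with a stated time of 72 h; a higher number here means a weaker inhibitor, a lower number a stronger inhibitor. In that test compound 1 (`Cc1cc(F)cc(C)c1Oc1ccc(C(C)(C)O)cc1-c1cn(C)c(=O)c2[nH]c(C(=O)NCc3ccc(C(=O)Nc4ccccc4N)cc3)cc12`) gives 240 nM, compound 2 (`Cn1cc(-c2cc(C(C)(C)O)ccc2OC2CC2)c2cc(C(=O)NCc3ccc(C(=O)NO)cc3)[nH]c2c1=O`) gives 420 nM, and compound 3 (`COc1ccc(C(C)(C)O)cc1-c1cn(C)c(=O)c2[nH]c(C(=O)NCc3ccc(C(=O)Nc4ccccc4N)cc3)cc12`) gives 420 nM. Compound 3 therefore stands level with compound 2, and the gap to the remaining compound lies within the scatter.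

The next compound is compound 4 (`Cn1cc(-c2cc(C(C)(C)O)ccc2OC2CC2)c2cc(C(=O)NCc3ccc(C(=O)Nc4ccccc4N)cc3)[nH]c2c1=O`), which departs from compound 3 in one place, with cyclopropyl in place of methyl on an oxygen on an aromatic ring. Methoxy thus becomes cyclopropyloxy.

Among the measured compounds shown here, only one measured step concerns the group on that same oxygen, an exchange of 4-fluoro-2,6-dimethylphenyl for methyl. It amounts to a 1.8-fold higher number from compound 1 to compound 3 (0.24 log units; within the scatter), so even that exchange did not move the number beyond the scatter. Compound 2 also carries cyclopropyloxy and reads 420 nM, but it differs from compound 4 at another place, which makes it only a loose guide.

No step beyond the scatter is expected in this assay, and no direction can be claimed with confidence. The estimated size is a 1.2-fold lower number from compound 3 to compound 4 (0.08 log units; within the scatter). For compound 4 the expected value is 350 nM, with an estimated range from 170 nM to 700 nM.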

Compound 4, half-maximal inhibitory concentration: 40 nM
Beside the measured number, compound 4's estimate is 8.8-fold (0.94 log units) above it, outside the stated range (below it).
By their numbers in this assay, from the lowest: compound 4; then compounds 1, 2 and 3 (each within the scatter of the next).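

In this assay, among the compounds shown here, the group on the oxygen on an aromatic ring turns out to matter: methoxy to cyclopropyloxy gives an 11-fold lower number from compound 3 to compound 4 (1.02 log units; beyond the scatter), and cyclopropyl in place of 4-fluoro-2,6-dimethylphenyl gives a 6.0-fold lower number from compound 1 to compound 4 (0.78 log units; beyond the scatter), whereas the one earlier step at this oxygen, a 1.8-fold higher number from compound 1 to compound 3 (0.24 log units; within the scatter), stayed within the scatter. Cyclopropyloxy alone does not set the number, since 2-aminophenyl in place of hydroxy on the amide-type nitrogen, with cyclopropyloxy present on both sides, gives an 11-fold lower number from compound 2 to compound 4 (1.02 log units; beyond the scatter), so the low value of compound 4 appears only with cyclopropyloxy and 2-aminophenyl together among these compounds. Nothing available explains why cyclopropyl stands apart from the other two groups on this oxygen.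

From the compounds shown here alone, it remains open whether the three-membered ring itself is what counts, or whether an ethyl, isopropyl or cyclobutyl group on the same oxygen would give a similar number. Going by these compounds, it is also open how methoxy would read with hydroxy on the amide-type nitrogen, so the size of the cyclopropyl step can be stated only with the 2-aminophenyl group in place.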